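A few compounds are considered here, and "the series" means these few. Any claim that something is new, unique, unknown or untested is made for them only; others in the source may bear on it.

Three compounds have numbers in a functional assay on HeLa cells (Homo sapiens) for antiproliferative activity, read by MTT assay, with a stated time of 72 h; a higher number here means a weaker inhibitor, a lower number a stronger inhibitor. Compound 1, `O=C1COc2ccc(-c3cccc(NS(=O)(=O)c4ccc(F)cc4)c3)cc2N1c1ccccc1`, gives 17700 nM there. Compound 2, `O=C1COc2ccc(-c3cnc(Cl)c(NS(=O)(=O)c4ccc(F)cc4)c3)cc2N1C1CCCCC1`, gives 14300 nM. Compound 3, `COc1ncc(-c2ccc3c(c2)N(C2CCCCC2)C(=O)CO3)cc1NS(=O)(=O)c1ccc(F)cc1`, gives 6100 nM, the lowest of the three numbers; the step of a 2.3-fold lower number from compound 2 to compound 3 (0.37 log units; beyond the scatter) lies beyond the scatter, and the gap to compound 1 is larger still. Compound 4, `COc1ncc(-c2ccc3c(c2)N(c2ccccc2)C(=O)CO3)cc1NS(=O)(=O)c1ccc(F)cc1`, is not yet measured. The change from compound 3 to compound 4 is phenyl in place of cyclohexyl on an amide-type nitrogen in a ring.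

Among the measured compounds shown here, no measured pair differs only in this one place. Compound 1 carries a phenyl on that nitrogen and compound 2 a cyclohexyl, but they also differ elsewhere, so their two values can be set side by side only loosely; they lie within the scatter of each other. For the measured compounds named here, the one measured step, from compound 2 to compound 3, concerns the other end of the molecule and says nothing about the amide nitrogen. On this thin basis, no step beyond the scatter is expected for the change to compound 4. Compound 4 is therefore estimated at 7000 nM, between 3000 nM and 18000 nM, which would mean an expected step of a 1.1-fold higher number from compound 3 to compound 4 (0.06 log units; within the scatter).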

Compound 4, half-maximal inhibitory concentration: 1530 nM
Compound 4: the middle estimate sits 4.6-fold (0.66 log units) above what was measured; the whole stated range lies above it.
By their numbers in this assay, from the lowest: compound 4; then compound 3; then compounds 2 and 1 (each within the scatter of the next).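

Among the compounds shown here, the amide-type nitrogen in the ring is not a silent position: in this assay, replacing cyclohexyl with phenyl gives a 4.0-fold lower number from compound 3 to compound 4 (0.60 log units; beyond the scatter) and makes compound 4 the lowest number so far. For the compounds shown here, this is the first comparison that isolates this nitrogen, since compound 1 and compound 2 also differ elsewhere, and it shows that the two groups are not interchangeable here. They have the same count of heavy atoms and neither has a hydrogen-bond donor, acceptor or net charge, so the counted difference is that one ring is aromatic and the other is not, but no measurement in hand explains the shift.

From the compounds shown here alone, it remains open whether an aromatic ring on this nitrogen is what matters, which a pyridyl ring, a benzyl group, a phenyl bearing a fluoro or methoxy group, or a simple methyl or longer chain could help to test. Going by these compounds, it is also open whether the same swap would give a similar step with the chloro group of compound 2 in place of the methoxy group.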